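From a long ester to a methyl ether

The source may hold more compounds than are shown below. What is called first, only, known or untested is meant among the compounds shown, and "the series" means these compounds.

Compound 1 `Nc1ccc(-c2cc(=O)c3c(N)c(F)cc(F)c3o2)cc1F` in a functional assay on HeLa cells (Homo sapiens) for cytotoxicity, read by neutral red uptake, with a stated time of 3 days (on this read-out higher numbers stand for weaker inhibition and lower numbers for stronger inhibition), gives > 100000 nM, which is a limit of the assay rather than a number.
Compound 2 `CN(C)CCC(=O)OCc1c(F)c(N)c2c(=O)cc(-c3ccc(N)c(F)c3)oc2c1F` gives 11000 nM in this assay.
Compound 3 `CCCCCCCCCC(=O)OCc1c(F)c(N)c2c(=O)cc(-c3ccc(N)c(F)c3)oc2c1F` gives > 100000 nM in this assay, again only a limit.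

Compound 3 thus stands at the limit of > 100000 nM in this assay, at which 2 of the 3 values shown sit, with no number of its own. Compound 4 `COCc1c(F)c(N)c2c(=O)cc(-c3ccc(N)c(F)c3)oc2c1F` differs from it by methyl in place of nonylcarbonyl on an oxygen on a saturated carbon. Among the measured compounds shown here, two measured steps concern the same side chain: an at least 9.0-fold lower number from compound 1 to compound 2 (0.95 log units; beyond the scatter) and an at least 9.0-fold higher number from compound 2 to compound 3 (0.95 log units; beyond the scatter). Neither involves a methyl ether, so they only show that this position can shift the result strongly in either direction. Compound 1 and compound 3 both sit at the limit of > 100000 nM in this assay, at which 2 of the 3 values shown sit. Compound 4 is therefore expected to stay near that limit, an expected a number no higher from compound 3 to compound 4 (the limit leaves the size open), giving an estimate of 100000 nM with a range from 20000 nM to 300000 nM.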

Compound 4, half-maximal inhibitory concentration: > 100000 nM
Compound 4 ended at the assay's limit (the forecaster's own chance of this, stated with the estimate: 70%); the middle value lies on the limit itself.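

In this assay, putting methyl in place of (2-(dimethylamino)ethyl)carbonyl on this oxygen gives an at least 9.0-fold higher number from compound 2 to compound 4 (0.95 log units; beyond the scatter). A short methyl and a long nonylcarbonyl thus end alike at a limit, and of the compounds on this oxygen only compound 2, with its dimethylamino group, gives a number: the limit of > 100000 nM in this assay, at which 3 of the 4 values shown sit.

The steps from compound 1 and from compound 3 to compound 4 cannot be read, as both ends of each are limits. Still open, going by these compounds, is whether the amine alone is enough, or whether the ester is needed too; a methyl ether chain ending in a dimethylamino group would separate the two.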